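The source may report more compounds than this note shows. Statements on the series, on what has been measured and on what is new or still open speak of the compounds shown alone.

In an ADME assay on L02 cells (Homo sapiens) for cytotoxicity, read by MTT assay, with a stated time of 72 h (a higher number here means a weaker inhibitor, a lower number a stronger inhibitor), compound 3 `Cn1nc(-c2nnc(-c3ccc(Cl)cc3)o2)c2ccccc21` gives only a limit, > 100000 nM. Compound 1 `Cn1nc(-c2nnc(-c3ccccc3Cl)o2)c2ccccc21` likewise reaches only a limit, > 100000 nM. Compound 2 `COc1ccc(-c2nnc(-c3nn(C)c4ccccc34)o2)cc1` also stops at a limit, > 100000 nM. The step that the two limits leave unreadable from compound 1 to compound 3 and the step that the two limits leave unreadable from compound 2 to compound 3 therefore carry no readable size, since the limit of > 100000 nM in this assay, at which 3 of the 3 values shown sit, is where all three values sit. Compound 4 `Cn1nc(-c2nnc(-c3ccc(Br)cc3)o2)c2ccccc21` differs from compound 3 by bromo in place of chloro on an aromatic carbon. Going by the values given here, no measured step offers a readable size for such a change, so compound 4 is expected to remain at the limit in this assay, with no step beyond the scatter, a step that the limit leaves unreadable from compound 3 to compound 4. The estimate for compound 4 is 120000 nM, within 50000 nM to 300000 nM.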

Compound 4, half-maximal inhibitory concentration: > 100000 nM
Compound 4 ended at the assay's limit (the forecaster's own chance of this, stated with the estimate: 85%); the middle value lies beyond the limit too.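

In this assay, compound 4 gives only a limit, > 100000 nM. Its steps from compound 1, compound 2 and compound 3 therefore cannot be read: the limit of > 100000 nM in this assay, at which 4 of the 4 values shown sit. The compounds shown leave open how large any of these changes really is.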